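Swapping the Amide Aryl Group in a Quinoline Amide Series

The source may report more compounds than this note shows. Statements on the series, on what has been measured and on what is new or still open speak of the compounds shown alone.

Three compounds share a core that carries an amide on one side and an amine on the other. Compound 1 `CCN1CCN(c2cc(C)c3cc(NC(=O)c4cccc(F)c4)ccc3n2)CC1` gives 24900 nM in a functional assay on SK-BR-3 cells (Homo sapiens) for antiproliferative activity, read by MTT assay, with a stated time of 72 h; on this read-out lower numbers stand for stronger inhibition and higher numbers for weaker inhibition. Compound 2 `Cc1cc(N2CCCCC2)nc2ccc(NC(=O)c3ccc(Cl)c(Cl)c3)cc12` gives 42500 nM in this assay, and compound 3 `CNc1cc(C)c2cc(NC(=O)c3ccc(Cl)c(Cl)c3)ccc2n1` gives 6350 nM. Among these three numbers, compound 1 stands second highest: its value sits within the scatter of compound 2, while compound 3 lies lower by a margin beyond the scatter.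

For the measured compounds named here, the only single-point step measured so far, a 6.7-fold lower number from compound 2 to compound 3 (0.83 log units; beyond the scatter), concerns the amine end of the core, not the amide end.

Compound 4 `CCN1CCN(c2cc(C)c3cc(NC(=O)c4ccc(C)cc4)ccc3n2)CC1` differs from compound 1 at the amide end: 4-methylphenyl in place of 3-fluorophenyl on a carbonyl carbon. Going by the values given here, no measured step touches that position, so nothing in these data predicts a shift in one direction or the other. The expectation for compound 4 is therefore a number close to that of compound 1, with a 1.0-fold higher number from compound 1 to compound 4 (0.00 log units; within the scatter) expected to stay within the scatter. The estimate for compound 4 in this assay is 25000 nM, expected to fall between 8000 nM and 80000 nM.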

Compound 4, half-maximal inhibitory concentration: 11400 nM
Estimate against measurement, compound 4: 2.2-fold (0.34 log units) above, within the range that was stated.
By their numbers in this assay, from the lowest: compounds 3 and 4 (each within the scatter of the next); then compounds 1 and 2 (each within the scatter of the next).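

For the compounds shown here, changing 3-fluorophenyl to 4-methylphenyl on a carbonyl carbon gives a 2.2-fold lower number from compound 1 to compound 4 (0.34 log units; beyond the scatter) in this assay and this modest step is the first sign that the amide end of the core also moves the number. Going by these compounds alone, the only earlier single-place step lay at the amine end, so the aryl group on the carbonyl now counts as a position that responds, even though the two groups have the same count of heavy atoms and one six-membered aromatic ring each. No measured evidence here explains why this swap lowers the number.

With a single pair, the methyl group, the loss of fluorine and the change of ring position cannot be told apart. On these data alone, a plain phenyl or a 4-methoxyphenyl group on the carbonyl would help to separate them, and how either would read at this position remains open.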